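Extending the Side Chain of Compound 1

This account rests on a few compounds, and the source may have more. Where it says the series, first, only, none or still open, it means among the compounds named here.

Of the compounds shown here, three with a shared core have been measured. Compound 1 `C[C@H](NC(=O)CN(c1nc(Cl)nc2[nH]cnc12)C1CC1)C(=O)OCc1ccccc1` gives 23% in a functional assay on the whole organism (Tail, strain ICR) with Mus musculus as the target, in the tail flick test, with a stated time of 150 min, at a dose of 25 umol/kg by the oral route (a higher number here means a stronger effect of the compound at the dose given, a lower number a weaker effect), and stands highest of the three numbers. Compound 2 `O=C(O)[C@@H]1CCCN1C(=O)CN(c1nc(Cl)nc2[nH]cnc12)C1CC1` gives 7.29% in this assay, and compound 3 `N=C(N)NCCC[C@H](NC(=O)CN(c1nc(Cl)nc2[nH]cnc12)C1CC1)C(=O)O` gives 7.19% in this assay; both lie beyond the scatter below compound 1, compound 2 as the nearest and compound 3 as the furthest. Compound 4 `O=C(CN(c1nc(Cl)nc2[nH]cnc12)C1CC1)N[C@@H](CCC(=O)OCc1ccccc1)C(=O)OCc1ccccc1` has not yet been measured. It differs from compound 1 in one place: (benzyloxycarbonyl)methyl in place of hydrogen on a saturated chain carbon, two bonds along the chain from an amide-type nitrogen and a carbonyl carbon. Within the data shown here, no measured pair shows this change, so its size is unknown. In this assay the expected step is a number 5 percentage points lower from compound 1 to compound 4 (within the scatter), within the scatter or slightly downward. Compound 4 is therefore estimated at 18%, expected between 5% and 35%.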

Compound 4, a percentage reported as activity, at one dose (the size of the read-out at that dose, not a potency): 44.5%
Compound 4: middle estimate off by 26.5 percentage points, on the low side, outside the stated range (above it).
By their numbers in this assay, from the lowest: compounds 3 and 2 (each within the scatter of the next); then compound 1; then compound 4.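

In this assay, (benzyloxycarbonyl)methyl in place of hydrogen on this saturated chain carbon brings a number 21.5 percentage points higher from compound 1 to compound 4 (beyond the scatter) and so shows that this position accepts a group of 11 heavy atoms with a gain in effect. Among these compounds, this is the first change at a single place that can be read. No measurement shown accounts for the gain. As far as these compounds go, it remains open whether a carboxylic acid or a methyl ester at the end of this chain would keep the step, and whether the six-membered aromatic ring is needed for it.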